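The source may hold more compounds than are shown below. What is called first, only, known or untested is meant among the compounds shown, and "the series" means these compounds.

Measured so far:
Compound 1 `CCCCNc1ccnc2cc(Cl)ccc12` — 7090 nM
Compound 2 `CCCCNc1ccnc2cc(F)ccc12` — 2090 nM

For the measured compounds named here, in a functional assay on MDA-MB-468 cells (Homo sapiens) for cytotoxicity, read by sulforhodamine B assay, with a stated time of 48 h, in the presence of a further agent that is not named here (on this read-out lower numbers stand for stronger inhibition of growth and higher numbers for weaker inhibition of growth), compound 1 gives 7090 nM, the higher of the two numbers; its nearest neighbour is compound 2, and the one measured step, a 3.4-fold lower number from compound 1 to compound 2 (0.53 log units; beyond the scatter), is fluoro in place of chloro on an aromatic carbon. Compound 3 `CN(C)CCNc1ccnc2cc(Cl)ccc12` differs from compound 1 instead at the chain: dimethylamino in place of ethyl on a saturated chain carbon, two bonds along the chain from a nitrogen on an aromatic ring. Going by the values given here, no measured step touches this chain, so nothing measured bears on the change, and no step beyond the scatter is expected in either direction. Compound 3 is expected to give about 6000 nM, within 1500 nM to 24000 nM. The expected step is a 1.2-fold lower number from compound 1 to compound 3 (0.07 log units; within the scatter).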

Compound 3, concentration for 50% growth inhibition: 6500 nM
The estimate for compound 3 lay 1.1-fold (0.03 log units) below the measured number; low and high end bracket the measured number.
By their numbers in this assay, from the lowest: compound 2; then compounds 3 and 1 (each within the scatter of the next).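

In this assay, placing dimethylamino where compound 1 has ethyl gives a 1.1-fold lower number from compound 1 to compound 3 (0.04 log units; within the scatter), so this change on the saturated chain carbon leaves the growth-inhibition number within the scatter. The earlier compounds shown here showed a step only at the ring halogen, whereas this result shows that the chain end can gain a nitrogen with no measurable change here. Nothing available explains this result.

Open, on these data alone, is whether a longer chain, a piperidine ring or a carboxylic acid at this position would behave alike. Also open, as far as these compounds go, is how the 2-(dimethylamino)ethyl chain behaves alongside fluoro on the ring.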